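Series notes: from pyrimidin-5-yl to 4-(trifluoromethyl)benzyl

The compounds below may be only part of what the source reports. "The series", "measured", "known", "first", "only" and "open" are said of these compounds alone.

Measured in a functional assay on HCT-116 cells (Homo sapiens) for inhibition, read by MTT assay, with a stated time of 72 h; a higher number here means a weaker inhibitor of growth, a lower number a stronger inhibitor of growth:
- compound 1 `O[C@H](COCCOC[C@@H](O)Cc1cn(-c2cccs2)nn1)Cc1ccc(-c2ccccc2)cc1`: 33400 nM
- compound 2 `O[C@H](COCCOC[C@@H](O)Cc1cn(Cc2cccc(-c3ccccc3)c2)nn1)Cc1ccc(-c2ccccc2)cc1`: 7200 nM
- compound 3 `O[C@H](COCCOC[C@@H](O)Cc1cn(-c2cncnc2)nn1)Cc1ccc(-c2ccccc2)cc1`: > 100000 nM

Compound 3 has no number, only a limit of the assay: the limit of > 100000 nM in this assay, at which 1 of the 3 values shown sits.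

Compound 4 `O[C@H](COCCOC[C@@H](O)Cc1cn(Cc2ccc(C(F)(F)F)cc2)nn1)Cc1ccc(-c2ccccc2)cc1` carries 4-(trifluoromethyl)benzyl in place of pyrimidin-5-yl on an aromatic nitrogen.

Going by the values given here, the only measured step at this place is an at least 2.9-fold higher number from compound 1 to compound 3 (0.47 log units; beyond the scatter), which is beyond the scatter and open-ended, since one end of it is a limit. It shows that this place can move the read-out. Of the measured compounds, compound 2 is the nearest to compound 4, with a substituted benzyl group on the same nitrogen, and compound 2 gives 7200 nM. On that reading, a move to a lower number in this assay is expected, beyond the scatter, and the expected size is an at least 8.3-fold lower number from compound 3 to compound 4 (0.92 log units; beyond the scatter). The estimate rests on a single close neighbour, so the range is wide. For compound 4 the estimated value is 12000 nM, with an expected range of 4000 nM to 40000 nM.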

Compound 4, concentration for 50% growth inhibition: 2500 nM
Beside the measured number, compound 4's estimate is 4.8-fold (0.68 log units) above it, outside the stated range (below it).
By their numbers in this assay, from the lowest: compound 4; then compound 2; then compound 1. At a limit, above all of these: compound 3.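

Compound 3 is held at a limit of the assay, not a number: the limit of > 100000 nM in this assay, at which 1 of the 4 values shown sits.

In this assay, going by these compounds alone, the open-ended an at least 40-fold lower number from compound 3 to compound 4 (1.60 log units; beyond the scatter) and a 13-fold lower number from compound 1 to compound 4 (1.13 log units; beyond the scatter) show that this position spans a wider range than the earlier compounds revealed, with 4-(trifluoromethyl)benzyl well ahead of pyrimidin-5-yl and thiophen-2-yl on the aromatic nitrogen. The a 2.9-fold lower number from compound 2 to compound 4 (0.46 log units; beyond the scatter), with 4-(trifluoromethyl)phenyl in place of 3-phenylphenyl on the saturated chain carbon, shows that the group carried on that carbon also moves the read-out.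

From the compounds shown here alone, it remains open how much of the change belongs to the trifluoromethyl group and how much to the chain carbon, a question that plain benzyl would address. Also open, going by these compounds, is how an amine or a carboxylic acid on the benzyl ring would behave here.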